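The compounds below may be only part of what the source reports. "The series", "measured", "known", "first", "only" and "open" are said of these compounds alone.

Compound 1 `O=C1c2[nH]nc(NS(=O)(=O)c3ccc4ccccc4c3)c2CCN1CC1CCNCC1`: 94.1%
Compound 2 `CC(C)Cc1cc(CNS(=O)(=O)c2ccc3ccccc3c2)nn1-c1ccccc1`: 67.8%

In an assay on isolated protein for binding affinity to 5-hydroxytryptamine receptor 6 (Homo sapiens), tested at 10 uM (on this read-out lower numbers stand for less inhibition and higher numbers for more inhibition at the one concentration tested (going by the name of the read-out)), compound 2 gives 67.8%, the lower of the two numbers; compound 1 gives 94.1%, a gap beyond the scatter. Compound 3 `CC(C)Cc1cc(CNS(=O)(=O)c2c(Cl)cccc2Cl)nn1-c1ccccc1` differs from compound 2 in one place: 2,6-dichlorophenyl in place of naphthalen-2-yl on a sulfonyl sulfur. For the measured compounds named here, no measured pair shows this change, so the expectation rests on compound 2 alone. The step is expected to be a number 22.8 percentage points lower from compound 2 to compound 3 (beyond the scatter), a decrease beyond the scatter, since compound 2 already stands lowest. For compound 3 the expected value in this assay is 45%, within a range from 15% to 75%.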

Compound 3, a percentage reported as inhibition, at one concentration (the size of the read-out at that concentration, not a potency): 59.4%
Compound 3: the middle estimate sits 14.4 percentage points below what was measured; measured number inside the range.
By their numbers in this assay, from the lowest: compounds 3 and 2 (each within the scatter of the next); then compound 1.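

In this assay, 2,6-dichlorophenyl in place of naphthalen-2-yl on a sulfonyl sulfur gives a number 8.4 percentage points lower from compound 2 to compound 3 (within the scatter). At this position, then, the read-out does not separate the two-ring naphthalen-2-yl from a single ring carrying two chlorine atoms. Nothing available explains why these two groups give such close values. From the compounds shown here alone, it remains open whether an unsubstituted phenyl, or a phenyl bearing an amine or a carboxylic acid, would give a similar number on this sulfonyl sulfur. Going by these compounds, whether 2,6-dichlorophenyl would give a similar result on the core of compound 1 also remains open.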